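The compounds below may be only part of what the source reports. "The series", "measured", "known", "first", "only" and "open" are said of these compounds alone.

Measured so far:
compound 1 `COCc1nc2nc(C)cc(Nc3ccc(S(F)(F)(F)(F)F)cc3)n2n1`: 2.8
compound 2 `Cc1cc(Nc2ccc(C(F)(F)F)cc2)n2nc(C3CC3)nc2n1`: 3.3
compound 3 `Cc1cc(Nc2ccc(Cl)cc2)n2nc(C(C)C)nc2n1`: 3.2

In a physicochemical assay for lipophilicity, at pH 7.4 (a higher number here means a more lipophilic compound, a lower number a more polar compound), compound 2 gives the highest of the three numbers shown. Compound 3 sits a little lower, within the scatter, so the two cannot be told apart; compound 1 sits lower by a margin beyond the scatter. Within the data shown here, no step between measured compounds that differ in one place is available, so the three values are read on their own.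

Compound 4 `CCOc1nc2nc(C)cc(Nc3ccc(C(F)(F)F)cc3)n2n1` is not yet measured. It differs from compound 2 as follows: ethoxy in place of cyclopropyl on an aromatic carbon

Given that one hydrogen-bond acceptor enters and no ring remains in ethoxy in place of cyclopropyl on an aromatic carbon, a small downward step is expected, close to the scatter. For compound 4 the estimate is 3, with a range of 2.6 to 3.4. The expected step is a number 0.30 log units lower from compound 2 to compound 4 (within the scatter).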

Compound 4, distribution coefficient: 3.1
Compound 4: middle estimate off by 0.10 log units, on the low side; the range from low to high includes it.
By their numbers in this assay, from the lowest: compounds 1, 4, 3 and 2 (each within the scatter of the next, the first and the last beyond it).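

In this assay, among these compounds, the first comparison that differs in one place puts ethoxy in place of cyclopropyl on an aromatic carbon, between two ring nitrogen atoms, and gives a number 0.20 log units lower from compound 2 to compound 4 (within the scatter) as the step. With the rest of compound 2 kept, losing the three-membered ring and gaining a hydrogen-bond acceptor at this position leaves a step that cannot be separated from the scatter. Nothing measured here gives a reason for the size of this step.

As far as these compounds go, whether an amine or a carboxylic acid at this position would give a step beyond the scatter remains open. Also open, from the compounds shown here alone, is whether the same change would give a similar step with a group other than trifluoromethyl on the aniline ring.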